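The source may report more compounds than this note shows. Statements on the series, on what has been measured and on what is new or still open speak of the compounds shown alone.

Working notes on the series. The shared core of compound 1 `Nc1nc(NCc2cccs2)nc2sc(-c3ccco3)nc12` carries a thiophen-2-yl on a saturated chain carbon bound to a nitrogen on an aromatic ring; in an assay on CHO cells for displacement of a labelled ligand from adenosine receptor A3 (Homo sapiens), read by scintillation counting, with a stated time of 120 min (on this read-out lower numbers stand for stronger inhibition and higher numbers for weaker inhibition), compound 1 gives 6.43 nM. Compound 2 `Nc1nc(NCc2ccncc2)nc2sc(-c3ccco3)nc12` gives 827 nM, and compound 3 `Nc1nc(NCc2ccco2)nc2sc(-c3ccco3)nc12` gives 4.72 nM. Compound 3 sits within the scatter of compound 1, as seen in a 1.4-fold lower number from compound 1 to compound 3 (0.13 log units; within the scatter), while a 180-fold lower number from compound 2 to compound 3 (2.24 log units; beyond the scatter) and a 130-fold higher number from compound 1 to compound 2 (2.11 log units; beyond the scatter) set compound 2 far apart from both.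

Compound 4 `Nc1nc(NCc2ccccn2)nc2sc(-c3ccco3)nc12` differs from compound 3 by pyridin-2-yl in place of furan-2-yl on a saturated chain carbon bound to a nitrogen on an aromatic ring. Going by the values given here, no measured step tests pyridin-2-yl itself. The step that bears on it is the one to a six-membered ring with one nitrogen, pyridin-4-yl, which was large in both a 130-fold higher number from compound 1 to compound 2 (2.11 log units; beyond the scatter) and a 180-fold lower number from compound 2 to compound 3 (2.24 log units; beyond the scatter), whereas the swap between the two five-membered rings, a 1.4-fold lower number from compound 1 to compound 3 (0.13 log units; within the scatter), stayed within the scatter. Because of a 180-fold lower number from compound 2 to compound 3 (2.24 log units; beyond the scatter) a higher number is expected for compound 4, though with pyridin-2-yl untested its size is uncertain, so a step of a 25-fold higher number from compound 3 to compound 4 (1.41 log units; beyond the scatter) is expected. Compound 4 is therefore estimated at 120 nM, within 15 nM to 900 nM.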

Compound 4, inhibition constant: 59 nM
Estimate against measurement, compound 4: 2.0-fold (0.31 log units) above, and the stated range covers the measured number.
By their numbers in this assay, from the lowest: compounds 3 and 1 (each within the scatter of the next); then compound 4; then compound 2.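

The two pyridines are not interchangeable at this place: in this assay, pyridin-2-yl in place of pyridin-4-yl gives a clear gain (a 14-fold lower number from compound 2 to compound 4 (1.15 log units; beyond the scatter)), so the large loss seen with pyridin-4-yl does not apply to every six-membered ring with one nitrogen. Pyridin-2-yl still falls short of both five-membered rings, with a large step from the furan-2-yl compound (a 13-fold higher number from compound 3 to compound 4 (1.10 log units; beyond the scatter)) and a modest one from the thiophen-2-yl compound (a 9.2-fold higher number from compound 1 to compound 4 (0.96 log units; beyond the scatter)). Nothing shown here accounts for the gap between the two pyridines.

Open, from the compounds shown here alone, is where pyridin-3-yl or a plain phenyl ring would fall relative to these values. Also open, going by these compounds, is whether a longer chain in place of the methyl of (pyridin-2-yl)methyl would keep the same order.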